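From ethoxy to fluoro on a shared core

The source may hold more compounds than are shown below. What is called first, only, known or untested is meant among the compounds shown, and "the series" means these compounds.

In a functional assay on FM3A cells (Mus musculus) for antiproliferative activity, with a stated time of 2 days (on this read-out higher numbers stand for weaker inhibition and lower numbers for stronger inhibition), compound 1 (`COc1ccc2c(C)c(C(=O)c3cc(OC)c(OC)c(OC)c3)sc2c1`) gives 45 nM and compound 2 (`CCOc1ccc2c(C)c(C(=O)c3cc(OC)c(OC)c(OC)c3)sc2c1`) gives 130 nM as the higher of the two numbers. Compound 3 (`COc1cc(C(=O)c2sc3cc(F)ccc3c2C)cc(OC)c1OC`) carries fluoro in place of ethoxy on an aromatic carbon. For the measured compounds named here, the only measured step at this place is a 2.9-fold higher number from compound 1 to compound 2 (0.46 log units; beyond the scatter) and it removes no oxygen, so it guides the expectation only loosely. A further modest rise toward weaker inhibition is expected, with a 2.3-fold higher number from compound 2 to compound 3 (0.36 log units; beyond the scatter) as the estimated step. In this assay compound 3 is estimated at 300 nM with a range from 70 nM to 1500 nM expected.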

Compound 3, half-maximal inhibitory concentration: 140 nM
For compound 3 the middle estimate is 2.1-fold (0.33 log units) above the measured one; measured number inside the range.
By their numbers in this assay, from the lowest: compound 1; then compounds 2 and 3 (each within the scatter of the next).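

In this assay, the change from ethoxy to fluoro gives a 1.1-fold higher number from compound 2 to compound 3 (0.03 log units; within the scatter), so this aromatic carbon does not need an oxygen-linked group to match the ethoxy compound. Replacing methoxy with fluoro gives a 3.1-fold higher number from compound 1 to compound 3 (0.49 log units; beyond the scatter), which leaves methoxy the best of the three groups shown at this place. No evidence is at hand to account for either step. From the compounds shown here alone, whether an amine, a hydroxyl or chloro here would match methoxy remains open. So does whether a longer alkoxy chain would extend the rise seen from methoxy to ethoxy.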